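Biaryl Replacing Triflate: Cytotoxicity Expected Unchanged

The source may hold more compounds than are shown below. What is called first, only, known or untested is meant among the compounds shown, and "the series" means these compounds.

Compound 1, `C=C[C@@](C)(/C=C/c1ccc(OS(=O)(=O)C(F)(F)F)cc1)CCC=C(C)C`, in a functional assay on HepG2 cells (Homo sapiens) for cytotoxicity, with a stated time of 72 h (on this read-out higher numbers stand for an effect only at larger amounts of compound and lower numbers for an effect already at smaller amounts), gives > 52000 nM, which is a limit of the assay and not a number. Compound 2, `C=C[C@@](C)(/C=C/c1ccc(OS(=O)(=O)c2ccc(C)cc2)cc1)CCC=C(C)C`, in this assay gives > 52000 nM, again a limit. Compound 3, `C=C[C@@](C)(/C=C/c1ccc(O)cc1)CC/C=C(\C)C(=O)OCC`, in this assay gives > 52000 nM, also a limit.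

Compound 1 therefore stands nowhere in particular among the numbers shown: it sits at the limit, and so does every other value in the set, (the limit of > 52000 nM in this assay, at which 3 of the 3 values shown sit). Going by the values given here, the single step between measured compounds, a step that the two limits leave unreadable from compound 1 to compound 2, is left unreadable by the two limits, so it says nothing about how large an effect a change on this part of the core may have.

Compound 4, `C=C[C@@](C)(/C=C/c1ccc(-c2ccc(F)cc2)cc1)CCC=C(C)C`, differs from compound 1 in one place: 4-fluorophenyl in place of ((trifluoromethyl)sulfonyl)oxy on an aromatic carbon. Among the compounds with values here, no measured step bears on this change; the only step available, a step that the two limits leave unreadable from compound 1 to compound 2, cannot be read at all. What remains is the position of compound 1 itself. Because compound 1 sits at the limit (the limit of > 52000 nM in this assay, at which 3 of the 3 values shown sit), compound 4 is expected to show no step beyond the scatter, a step that the limit leaves unreadable from compound 1 to compound 4, and most likely to report a limit as well. Compound 4 is estimated at 60000 nM, with a range from 20000 nM to 150000 nM.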

Compound 4, half-maximal effective concentration: > 52000 nM
Compound 4: no number, only a limit; the forecaster's own chance of this, stated with the estimate: 70%; the middle value is on the limit's open side.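

In this assay compound 4 gives only a limit and not a number, and compound 1 does too, so the step between compound 1 and compound 4 cannot be read. The compounds shown leave open what size of effect any change on the shared core can have, because none of their values is a number: the limit of > 52000 nM in this assay, at which 4 of the 4 values shown sit.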